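A few compounds are considered here, and "the series" means these few. Any claim that something is new, unique, unknown or untested is made for them only; others in the source may bear on it.

Compound 1 `Cc1ccccc1/C(CCN1CCN(c2ccccn2)CC1)=N/O` gives 4.2 nM in a functional assay on HEK293 cells with D(4) dopamine receptor (Homo sapiens) as the target, read by FLIPR; a higher number here means that more compound is needed for the effect, a lower number that less compound is needed. Compound 2 `CO/N=C(\CCN1CCN(c2ccccn2)CC1)c1ccccc1C`, which carries a methyl in place of hydrogen on an oxygen, gives 74 nM in this assay, and that change is an 18-fold higher number from compound 1 to compound 2 (1.25 log units; beyond the scatter). Compound 3 `CO/N=C(/CCN1CCN(c2ccccn2)CC1)c1ccccc1C` gives 40.1 nM in this assay; the step of a 1.8-fold lower number from compound 2 to compound 3 (0.27 log units; within the scatter) rests on (the fact that compounds 2 and 3 differ only in the configuration as drawn), so the two geometric isomers sit within the scatter of each other.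

Among these three numbers compound 2 holds the highest; compound 3 lies nearest within the scatter, and compound 1 lies furthest away.

Compound 4 `CO/N=C(\CCN1CCN(c2ccccn2)CC1)c1cc(C)cc(C)c1` is not yet measured in this assay. Compared with compound 2 it shows (3,5-dimethylphenyl in place of 2-methylphenyl on a carbon with a double bond to nitrogen). Neither measured step bears on this change: the step from compound 1 to compound 2 concerns the oxygen substituent, and the step from compound 2 to compound 3 concerns the drawn configuration alone, while the aryl group stays the same throughout. There is therefore no measured guide for the size or direction of the step, and the expectation is for no change beyond the scatter, with a broad range on either side.

Compound 4 is estimated at 110 nM, between 25 nM and 500 nM, in this assay; the expected step is a 1.5-fold higher number from compound 2 to compound 4 (0.17 log units; within the scatter).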

Compound 4, half-maximal effective concentration: 175 nM
Estimate against measurement, compound 4: 1.6-fold (0.20 log units) below; the measured number falls inside the stated range.
By their numbers in this assay, from the lowest: compound 1; then compounds 3 and 2 (each within the scatter of the next); then compound 4.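

Up to compound 3 the aryl group on the carbon with a double bond to nitrogen never varied, so this is the first reading of that place in this assay. There, 3,5-dimethylphenyl in place of 2-methylphenyl gives a 2.4-fold higher number from compound 2 to compound 4 (0.37 log units; beyond the scatter), which shows that the number responds to the aryl group and does so beyond the scatter, although this step is smaller than the one at the oxygen, an 18-fold higher number from compound 1 to compound 2 (1.25 log units; beyond the scatter). Among these compounds, the only explanatory information available concerns the drawn configuration of the double bond, and nothing given here speaks to the reason for this aryl step.

The exchange alters both the methyl substitution and its place on the ring, so the step cannot be assigned to either alone, and a plain phenyl, a 3-methylphenyl or a 3,5-dichlorophenyl group at this place would be needed to separate them. As far as these compounds go, it also remains open whether the same aryl exchange would give a step of similar size and direction in the free oxime of compound 1 or in the other double-bond geometry of compound 3.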